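The source may hold more compounds than are shown below. What is called first, only, known or untested is meant among the compounds shown, and "the series" means these compounds.

Compound 2 `Cc1cc(CCC#N)cc(C)c1Oc1cc(Nc2ccc(C#N)cc2)c(N)cc1CNC1CC1` stands highest of the two numbers in a physicochemical assay for solubility, read by HPLC, in phosphate buffer, with a stated time of 4 h, at pH 7.4, tested at 10 mg/mL; a higher number here means a more soluble compound, a lower number a less soluble compound: compound 2 gives 13.6 ug/mL. For the measured compounds named here, its only neighbour is compound 1 `Cc1cc(CCC#N)cc(C)c1Oc1cc(Nc2ccc(C#N)cc2)c(N)cc1C(=O)N(C)C`, which in this assay gives 1.08 ug/mL, and the one measured step is a 13-fold higher number from compound 1 to compound 2 (1.10 log units; beyond the scatter). Compound 3 `Cc1cc(CCC#N)cc(C)c1Oc1cc(Nc2ccc(C#N)cc2)c(N)cc1COC(=O)C1CC1` differs from compound 2 in one place: (cyclopropylcarbonyl)oxy in place of cyclopropylamino on a saturated chain carbon bound to an aromatic carbon. Going by the values given here, no measured pair shows this exact change. The step from compound 1 to compound 2 bears on it only in that the cyclopropylamino group which entered there now leaves again, and the entering group counts no hydrogen-bond donor. On that basis the gain seen in this assay on going to compound 2 is not expected to persist, and compound 3 is expected to sit nearer to compound 1. The expected step is a 6.8-fold lower number from compound 2 to compound 3 (0.83 log units; beyond the scatter). Compound 3 is estimated at 2 ug/mL, with a range of 0.5 ug/mL to 8 ug/mL.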

Compound 3, solubility: 1.64 ug/mL
Estimate against measurement, compound 3: 1.2-fold (0.09 log units) above; measured number inside the range.
By their numbers in this assay, from the lowest: compounds 1 and 3 (each within the scatter of the next); then compound 2.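

In this assay, the change on a saturated chain carbon bound to an aromatic carbon gives an 8.3-fold lower number from compound 2 to compound 3 (0.92 log units; beyond the scatter), so the higher number of compound 2 is not kept once (cyclopropylcarbonyl)oxy replaces cyclopropylamino. The three-membered carbon ring is common to both groups, whereas the nitrogen and the hydrogen-bond donor of cyclopropylamino are absent from the entering group. With a 1.5-fold higher number from compound 1 to compound 3 (0.18 log units; within the scatter) as the other step, ((cyclopropylcarbonyl)oxy)methyl and dimethylcarbamoyl cannot be told apart in this assay.

From the compounds shown here alone, whether the higher number follows the amine nitrogen or the cyclopropylamino group as a whole remains open, and a primary amine or a carboxylic acid at the same place would bear on that. Nothing available accounts for the size of either step.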